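The source may report more compounds than this note shows. Statements on the series, on what has been measured and on what is new or still open speak of the compounds shown alone.

Compound 1 `Nc1ccccc1NC(=O)/C=C/c1ccc(Cn2cnc3c(Nc4cccc(Cl)c4)nc(Cl)nc32)cc1` gives 29.4% in a functional assay on NCI-H460 cells (Homo sapiens) for antiproliferative activity, read by CCK-8 assay, with a stated time of 72 h, tested at 8 uM (a higher number here means a stronger effect of the compound at the concentration tested, a lower number a weaker effect), which is the lower of the two numbers measured, while compound 2 `Nc1ccccc1NC(=O)c1ccc(Cn2cnc3c(Nc4cccc(Cl)c4)nc(Cl)nc32)cc1` gives 67% in this assay. Within the data shown here, the one measured step, a number 37.6 percentage points higher from compound 1 to compound 2 (beyond the scatter), changes only the linker between the amide and the shared core, and both compounds keep the same 3-chlorophenyl group on the nitrogen on an aromatic ring.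

Compound 3 `Nc1ccccc1NC(=O)/C=C/c1ccc(Cn2cnc3c(NCc4ccccc4)nc(Cl)nc32)cc1` keeps the linker of compound 1 and differs from it in the change (benzyl in place of 3-chlorophenyl on a nitrogen on an aromatic ring). Among the measured compounds shown here, no measured pair varies this part of the molecule, so the step to compound 2 does not bear on it and gives no direction. In the absence of a comparable step, compound 3 is expected to stay close to compound 1, so that a number 0.6 percentage points higher from compound 1 to compound 3 (within the scatter) is estimated to lie within the scatter. Compound 3 is therefore estimated at 30% in this assay, with a wide range from 10% to 55%.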

Compound 3, a percentage reported as inhibition, at one concentration (the size of the read-out at that concentration, not a potency): 49.1%
Compound 3: middle estimate off by 19.1 percentage points, on the low side; low and high end bracket the measured number.
By their numbers in this assay, from the lowest: compound 1; then compound 3; then compound 2.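

Among these compounds, this is the first look at the group on the nitrogen on an aromatic ring: in this assay, benzyl in place of 3-chlorophenyl gives a number 19.7 percentage points higher from compound 1 to compound 3 (beyond the scatter), so this position bears on the read-out even though both groups have the same count of heavy atoms and one six-membered aromatic ring of carbon only. Among the compounds shown here, the change removes a chlorine and adds a carbon at once, so the single step cannot separate the two. Nothing available here accounts for the step.

Among the compounds shown, benzyl occurs only with the linker of compound 1, so it remains open whether the step would carry over to the linker of compound 2. Also open, as far as these compounds go, is how a plain phenyl, a 3-chlorobenzyl or a longer chain such as phenethyl on this nitrogen would read in this assay.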